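Swapping (3-methylphenyl)amino for (2-methylphenyl)amino on the core

The source may report more compounds than this note shows. Statements on the series, on what has been measured and on what is new or still open speak of the compounds shown alone.

Compound 1 `Cc1cccc(Nc2nc(C)c(C(=O)/C=C/c3ccccc3Cl)s2)c1` stands at the edge of what a functional assay on NCI-H460 cells (Homo sapiens) for cytotoxicity, read by MTT assay (a lower number here means a stronger inhibitor, a higher number a weaker inhibitor), reports: compound 1 gives only > 25000 nM, which is a limit of the assay and not a number. Compound 3 `Cc1nc(Nc2ccc(Cl)c(Cl)c2)sc1C(=O)/C=C/c1ccc(Cl)cc1` likewise returns only a limit in this assay, > 25000 nM. Going by the values given here, compound 2 `Cc1cccc(Nc2nc(C)c(C(=O)/C=C/c3ccccc3)s2)c1` is the sole member with a numeric value, 21800 nM in this assay. Among the compounds with values here, the one measured step between compounds that differ in a single place, an at least 1.1-fold lower number from compound 1 to compound 2 (0.05 log units; that floor lies within the scatter), is a hydrogen in place of chloro on an aromatic carbon, and because of the limit of > 25000 nM in this assay, at which 2 of the 3 values shown sit, its size is known only as a floor. Compound 4 `Cc1ccccc1Nc1nc(C)c(C(=O)/C=C/c2ccccc2Cl)s1` differs from compound 1 by 2-methylphenyl in place of 3-methylphenyl on a nitrogen on an aromatic ring; cut one bond further out, the change reads (3-methylphenyl)amino to (2-methylphenyl)amino. Within the data shown here, no measured step touches this part of the shared core, so the step from compound 1 to compound 2 bears on it only by showing how weakly every member reads in this assay. Hence no step beyond the scatter is expected in this assay, in either direction. Compound 4 is estimated at 25000 nM, with a range from 12000 nM to 60000 nM, an expected step of a number no higher from compound 1 to compound 4 (the limit leaves the size open), and a fair chance that this assay again reports only a limit.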

Compound 4, half-maximal inhibitory concentration: > 25000 nM
Compound 4: only a limit was reported (the forecaster's own chance of this, stated with the estimate: 60%); the middle value lies on the limit itself.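

In this assay compound 4 gives > 25000 nM which is a limit of the assay and not a number. Going by these compounds alone, compound 1 also stands at a limit, so no step between compound 1 and compound 4 can be read: the limit of > 25000 nM in this assay, at which 3 of the 4 values shown sit. Going by these compounds, whether 2-methylphenyl in place of 3-methylphenyl on this nitrogen shifts the reading in this assay stays open.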